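The compounds below may be only part of what the source reports. "The series", "measured", "known", "first", "only" and "open" are said of these compounds alone.

In a functional assay on CHO cells for agonist activity at Free fatty acid receptor 1 (Homo sapiens) (a lower number here means that less compound is needed, a higher number that more compound is needed for the effect), three compounds share one core and differ only in the arm that carries the acid. Compound 1 `Cc1nc(-c2ccc(C(F)(F)F)cc2)sc1CNc1ccc(CC(=O)O)cc1` is known only by a limit of the assay, < 10000 nM. Compound 2 `O=C(O)CCCc1ccc(NCc2cccc(Oc3ccccc3)c2)cc1` gives 1120 nM in this assay. Compound 3 `O=C(O)/C=C/c1ccc(NCc2cccc(Oc3ccccc3)c2)cc1` gives 145 nM in this assay. Among the compounds with values here, compound 3 therefore holds the lowest of the two full numbers, and the gap to its nearest neighbour is the single measured step, a 7.7-fold lower number from compound 2 to compound 3 (0.89 log units; beyond the scatter), which lies beyond the scatter.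

Compound 4 `O=C(O)CSc1ccc(NCc2cccc(Oc3ccccc3)c2)cc1` has not yet been measured in this assay. It differs from compound 3 in one place: (carboxymethyl)sulfanyl in place of 2-carboxyethenyl on an aromatic carbon. Within the data shown here, no measured step shows this particular exchange. Among the measured compounds shown here, the only step that bears on it is a 7.7-fold lower number from compound 2 to compound 3 (0.89 log units; beyond the scatter), and it shows that reshaping the acid-bearing arm on this core shifts this assay by a modest amount. Compound 4 gives up the 2-carboxyethenyl that set compound 3 apart from compound 2 and takes on an arm that resembles neither of the two. A modest rise in the number is expected for compound 4, a 4.1-fold higher number from compound 3 to compound 4 (0.62 log units; beyond the scatter). Compound 4 is estimated to give 600 nM, with a range from 150 nM to 2500 nM.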

Compound 4, half-maximal effective concentration: 324 nM
Compound 4: middle estimate off by 1.9-fold (0.27 log units), on the high side, and the stated range covers the measured number.
By their numbers in this assay, from the lowest: compound 3; then compound 4; then compound 2.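

In this assay the arm on the aromatic carbon para to a large group keeps much of its low number with sulfur in the chain and one double bond fewer: the exchange of 2-carboxyethenyl for (carboxymethyl)sulfanyl brings a 2.2-fold higher number from compound 3 to compound 4 (0.35 log units; beyond the scatter) on the shared core. Set against 3-carboxypropyl, the same arm brings a 3.5-fold lower number from compound 2 to compound 4 (0.54 log units; beyond the scatter) and so shows that a number lower than that of 3-carboxypropyl is not tied to 2-carboxyethenyl alone. With these steps the three arms fall into a single order in this assay, with 2-carboxyethenyl lowest, (carboxymethyl)sulfanyl in the middle and 3-carboxypropyl highest, and every gap between them lies beyond the scatter.

Nothing measured here gives a reason for these differences between the arms. The compounds shown leave open how an arm joined through oxygen, such as carboxymethoxy, or a longer chain carrying the sulfur would read on this core, and whether an amide or a tetrazole could stand in place of the carboxylic acid.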